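Alkylating the amino group of a pyrazolyl-indazole amine

This account rests on a few compounds, and the source may have more. Where it says the series, first, only, none or still open, it means among the compounds named here.

Measured compounds in an assay on isolated protein for inhibition of tyrosine-protein kinase receptor UFO (Homo sapiens), with a stated time of 1.5 h; on this read-out lower numbers stand for stronger inhibition and higher numbers for weaker inhibition:
compound 1 `Nc1cccc2[nH]nc(Br)c12`: 486000 nM
compound 2 `Cn1cc(-c2n[nH]c3cc(N)ccc23)cn1`: 28800 nM
compound 3 `Cn1cc(-c2nn(C)c3cc(N)ccc23)cn1`: > 384000 nM

Compound 2 gives the lowest of the two numbers reported; compound 1 is its nearest neighbour, and the gap from compound 2 to compound 1 is beyond the usual scatter. For compound 3 the value is a limit of this assay, not a number.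

Compound 4 `CC(C)Nc1ccc2c(-c3cnn(C)c3)n[nH]c2c1` differs from compound 2 in one place: isopropyl in place of hydrogen on a nitrogen on an aromatic ring, which, read one bond further out, turns the amino group into an isopropylamino group.

Only one measured step exists among these compounds: an at least 13-fold higher number from compound 2 to compound 3 (1.12 log units; beyond the scatter). That step concerns methyl in place of hydrogen on an aromatic nitrogen, a different kind of nitrogen from the one changed here, so it bears on the present step only loosely. Within the data shown here, it shows that substitution on a nitrogen can weaken inhibition sharply, but no measured pair tests an alkyl group on the amino nitrogen itself.

Among the measured compounds shown here, with no direct precedent, compound 4 is expected to land close to compound 2, with a wide uncertainty that leans toward weaker inhibition. The step from compound 2 to compound 4 is estimated as a 1.6-fold higher number from compound 2 to compound 4 (0.19 log units; within the scatter). Compound 4 is thus estimated at 45000 nM, within a range from 8000 nM to 250000 nM.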

Compound 4, half-maximal inhibitory concentration: 46600 nM
Compound 4: the middle estimate sits 1.0-fold (0.02 log units) below what was measured, within the range that was stated.
By their numbers in this assay, from the lowest: compounds 2 and 4 (each within the scatter of the next); then compound 1.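

In this assay, placing isopropyl on the nitrogen on an aromatic ring gives a 1.6-fold higher number from compound 2 to compound 4 (0.21 log units; within the scatter), so this substitution is carried without a change that can be told from the scatter. Among these compounds, the earlier compounds offered no direct test at this nitrogen: their only step, methyl in place of hydrogen on an aromatic nitrogen, gives an at least 13-fold higher number from compound 2 to compound 3 (1.12 log units; beyond the scatter), which lies beyond the scatter. Across these two steps, then, adding an alkyl group to a nitrogen does not have the same outcome at both places, although the groups differ as well as the nitrogens, and nothing measured here gives a reason for the difference.

A single isopropyl group shows only that this one substituent leaves the number within the scatter of compound 2, not how far the nitrogen tolerates other groups. Still open, from the compounds shown here alone, is whether a longer chain ending in an amine, a cyclopropyl ring or a carboxylic acid at this place would leave the number unchanged, or move it clearly lower or higher in this assay.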